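A few compounds are considered here, and "the series" means these few. Any claim that something is new, unique, unknown or untested is made for them only; others in the source may bear on it.

Of the compounds shown here, three have been read in an ADME assay on HEK-293T cells (Homo sapiens) for cytotoxicity, read by CCK-8 assay, with a stated time of 48 h (a lower number here means a stronger inhibitor, a higher number a weaker inhibitor), and none of them gives a number. Compound 1 (`COc1ccc(NC(=O)NCCNS(=O)(=O)c2sccc2-c2ccc(C)cc2Oc2ccc(O)c(O)c2)cc1`) gives > 20000 nM, which is a limit. Compound 2 (`O=C(NCCNS(=O)(=O)c1cc(-c2ccccc2Oc2ccc(O)c(O)c2)cs1)Nc1cc(C(F)(F)F)cc(C(F)(F)F)c1`) gives > 50000 nM, also a limit. Compound 3 (`O=C(NCCNS(=O)(=O)c1ccc(-c2ccccc2O[C@H]2CC[C@H](O)CC2)s1)Nc1cc(Cl)cc(Cl)c1`) gives > 50000 nM, again a limit. Compound 1 therefore stands at the limit of > 20000 nM in this assay, at which 1 of the 3 values shown sits. The other two compounds stand at the limit of > 50000 nM in this assay, at which 2 of the 3 values shown sit.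

Compound 4 (`Cc1ccc(-c2ccsc2S(=O)(=O)NCCNC(=O)Nc2cc(Cl)cc(Cl)c2)c(Oc2ccc(O)c(O)c2)c1`) is the next to be read in this assay. It keeps the core of compound 1 and differs at one place: 3,5-dichlorophenyl in place of 4-methoxyphenyl on an amide-type nitrogen. In short, 3,5-dichlorophenyl takes the place of 4-methoxyphenyl on an amide-type nitrogen.

Within the data shown here, no pair of measured compounds differs at one place only, so no measured step gives the size of this change. The closest guide is compound 3, which carries the same 3,5-dichlorophenyl on a different core and gives > 50000 nM, a limit. No shift beyond the usual scatter is expected, and a further limit is the likeliest report. The expected change is a step that the limit leaves unreadable from compound 1 to compound 4. For compound 4 the estimate is 30000 nM, with an expected range of 12000 nM to 70000 nM.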

Compound 4, half-maximal inhibitory concentration: 6700 nM
Compound 4: the middle estimate sits 4.5-fold (0.65 log units) above what was measured, and the stated range ends above it.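

In this assay, compound 4 is the only one of the four compounds shown that gives a number and not a limit, so the place on the amide-type nitrogen is one where the reading of this core can be moved into the measurable range. Among these compounds, putting 3,5-dichlorophenyl in place of 4-methoxyphenyl at this place gives an at least 2.9-fold lower number from compound 1 to compound 4 (0.47 log units; beyond the scatter), a step beyond the scatter, and this is the first size available for any change. Compound 1, the starting point of that step, is a limit, so the step's full size cannot be read: the limit of > 20000 nM in this assay, at which 1 of the 4 values shown sits.

The compounds shown do not separate the arrival of the two chlorines from the departure of the methoxy group, and a plain phenyl, a 4-chlorophenyl or a 3-chlorophenyl on the core of compound 1 would divide the step between them. Among the compounds shown here, whether the same change gives a step of this kind on the other cores also stays open, since only this single pair differs at one place.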